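The compounds below may be only part of what the source reports. "The series", "measured", "known", "first", "only" and "open" are said of these compounds alone.

Measured so far:
Compound 1, `Cc1cccc(-c2n[nH]cc2N2CCCNCC2)c1`: in an assay on isolated protein for binding affinity to 5-hydroxytryptamine receptor 1E (Homo sapiens) (on this read-out lower numbers stand for stronger inhibition and higher numbers for weaker inhibition), compound 1 gives > 10000 nM, a limit of the assay.
Compound 2, `Cc1ccc(-c2n[nH]cc2N2CCCNCC2)cc1`: in this assay compound 2 gives > 10000 nM, a limit.
Compound 3, `Clc1ccc(-c2n[nH]cc2N2CCCNCC2)cc1`: in this assay compound 3 gives > 10000 nM, a limit.

Compound 1 therefore stands nowhere in particular on the numbers shown: its value is a limit, and the two further values are limits as well, so that all three compounds sit together at the limit of > 10000 nM in this assay, at which 3 of the 3 values shown sit. For the measured compounds named here, the one measured step between close neighbours, a step that the two limits leave unreadable from compound 2 to compound 3, is unreadable for the same reason. The unmeasured compound 4, `COc1cccc(-c2n[nH]cc2N2CCCNCC2)c1`, differs from compound 1 by methoxy in place of methyl on an aromatic carbon. Going by the values given here, no measured step involves a methoxy group, and the only step in this assay carries no readable size, so nothing in the data points to a direction for the change from compound 1 to compound 4. The expectation is that compound 4 also returns a limit rather than a number in this assay; the step from compound 1 to compound 4 is estimated as a step that the limit leaves unreadable from compound 1 to compound 4. Compound 4 is estimated at 15000 nM, within a range from 4000 nM to 60000 nM.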

Compound 4, inhibition constant: > 10000 nM
Compound 4: only a limit was reported; the forecaster's own chance of this, stated with the estimate: 80%; the middle value lies beyond the limit too.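

Compound 4, like compound 1, returns only a limit, so the change from compound 1 to compound 4 cannot be read: the limit of > 10000 nM in this assay, at which 4 of the 4 values shown sit. The compounds shown leave open how methyl, chloro and methoxy groups would compare in this assay if any gave a number.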